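A few compounds are considered here, and "the series" means these few. Any claim that something is new, unique, unknown or untested is made for them only; others in the source may bear on it.

Compound 1 `COc1ccc(C(=O)Nc2nc(-c3cc(OC)c(OC)c(OC)c3)cs2)cc1OC`: > 25000 nM (a limit of the assay, not a number)
Compound 2 `Cn1c(-c2cccc(Br)c2)cs/c1=N\C(=O)c1ccccc1`: 302 nM

Among the measured compounds shown here, in a functional assay on MDA-MB-231 cells (Homo sapiens), read by microscopy and transwell migration, with a stated time of 24 h (a higher number here means a weaker inhibitor, a lower number a stronger inhibitor), compound 2 gives 302 nM, the only true number so far. The result of compound 1 is a limit. Compound 3 `Cn1c(-c2cccc(Cl)c2)cs/c1=N\C(=O)c1ccccc1` differs from compound 2 in one place: chloro in place of bromo on an aromatic carbon. It carries chloro in place of bromo on an aromatic carbon, meta to a large group. For the measured compounds named here, no measured pair shows what this swap does, so no change beyond the usual scatter is expected in this assay. The estimated step is a 1.2-fold higher number from compound 2 to compound 3 (0.06 log units; within the scatter). The expected value for compound 3 is 350 nM, within an estimated range of 120 nM to 1000 nM.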

Compound 3, half-maximal inhibitory concentration: 367 nM
For compound 3 the middle estimate is 1.0-fold (0.02 log units) below the measured one; measured number inside the range.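

In this assay, chloro in place of bromo on this aromatic carbon gives a 1.2-fold higher number from compound 2 to compound 3 (0.08 log units; within the scatter). Among the compounds shown here, this is the first direct reading of a single change, and it shows that this position takes either halogen with no change that stands out from the scatter. As far as these compounds go, whether a different kind of group at this position, such as an amine, a carboxylic acid or a plain hydrogen, would keep the number in this range stays open. No measurement shown bears on why the two halogens give such close values.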